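Enlarging a side chain on an amide-linked amino acid

A few compounds are considered here, and "the series" means these few. Any claim that something is new, unique, unknown or untested is made for them only; others in the source may bear on it.

Compound 2 `COc1cc2c(cc1O)CCC(C)(CC(=O)N[C@@H](C)C(=O)O)O2` gives 100% in an ADME assay on SH-SY5Y cells (Homo sapiens) for cytotoxicity, read by MTT assay, with a stated time of 24 h, tested at 12.5 uM; a lower number here means a stronger effect, a higher number a weaker effect of the compound at the concentration tested; of the two numbers shown it is the higher, and its neighbour compound 1 `COc1cc2c(cc1O)CCC(C)(CC(=O)O)O2` gives 92%. The step of a number 8 percentage points higher from compound 1 to compound 2 (within the scatter) lies within the scatter. Compound 3 `COc1cc2c(cc1O)CCC(C)(CC(=O)N[C@H](C(=O)O)C(C)C)O2` differs from compound 2 by isopropyl in place of methyl on a saturated chain carbon bound to an amide-type nitrogen and a carbonyl carbon. Going by the values given here, no measured step covers such an alkyl enlargement, and the one step known shows little response. The estimated change a number 4 percentage points lower from compound 2 to compound 3 (within the scatter) is therefore nothing beyond the scatter, and compound 3 is expected to give about 96%, between 84% and 105%.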

Compound 3, a percentage reported as activity, at one concentration (the size of the read-out at that concentration, not a potency): 82.6%
Compound 3: the middle estimate sits 13.4 percentage points above what was measured, and the stated range ends above it.
By their numbers in this assay, from the lowest: compounds 3, 1 and 2 (each within the scatter of the next, the first and the last beyond it).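

In this assay, going by these compounds alone, this position does respond to the size of the side chain: isopropyl in place of methyl gives a number 17.4 percentage points lower from compound 2 to compound 3 (beyond the scatter) and is the first step here to pass the scatter. Set against the free acid, the (1-carboxy-2-methylpropyl)amino group gives a number 9.4 percentage points lower from compound 1 to compound 3 (within the scatter) and stays inside it, so only the comparison with the methyl side chain stands out. Nothing measured here explains this step.

On these data alone, whether a longer chain such as n-butyl, or a side chain carrying a phenyl ring or an amine, would lower the number further remains open. So does the effect of a methyl ester in place of the terminal carboxylic acid.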